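This account rests on a few compounds, and the source may have more. Where it says the series, first, only, none or still open, it means among the compounds named here.

Three pyrazoline compounds were tested in a functional assay on PC-3 cells (Homo sapiens) for cytotoxicity, read by MTT assay, with a stated time of 48 h; a higher number here means a weaker inhibitor, a lower number a stronger inhibitor. Compound 1, `CC1=NN(C(=O)c2ccc([N+](=O)[O-])cc2)C(c2ccccc2O)C1`, gives 36600 nM in this assay. Compound 2, `CC1=NN(C(=O)c2ccc(C)cc2)C(c2ccccc2O)C1`, gives 40600 nM in this assay. The change from compound 1 to compound 2 is methyl in place of nitro on an aromatic carbon, and it produced a 1.1-fold higher number from compound 1 to compound 2 (0.05 log units; within the scatter). Compound 3, `O=c1oc2ccccc2cc1C1=NN(S(=O)(=O)c2ccc([N+](=O)[O-])cc2)C(c2ccccc2)C1`, gives 46600 nM in this assay; its number and those of compounds 1 and 2 all lie within the scatter of one another, so no order among the three can be read.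

Compound 4, `Cc1ccc(S(=O)(=O)N2N=C(c3cc4ccccc4oc3=O)CC2c2ccccc2)cc1`, has not yet been measured. It differs from compound 3 by methyl in place of nitro on an aromatic carbon. The difference between the core of compound 3 and the core of compound 1 is not broken down here. The wording of the place is the same for both pairs, but for compound 3 to compound 4 the difference cut one bond further out reads 4-nitrophenyl to 4-methylphenyl, so this is the same kind of change rather than the same change. On that basis the step from compound 3 to compound 4 is expected to be a 1.1-fold higher number from compound 3 to compound 4 (0.03 log units; within the scatter), resting on the small step of a 1.1-fold higher number from compound 1 to compound 2 (0.05 log units; within the scatter). Compound 4 is therefore estimated to give 50000 nM in this assay, with a range from 25000 nM to 100000 nM.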

Compound 4, half-maximal inhibitory concentration: 48600 nM
Estimate against measurement, compound 4: 1.0-fold (0.01 log units) above; the range from low to high includes it.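

In this assay, methyl in place of nitro gave a 1.0-fold higher number from compound 3 to compound 4 (0.02 log units; within the scatter), and this step agrees with the one seen on the core of compound 1: the same change on two cores in this assay, a 1.1-fold higher number (0.05 log units; within the scatter) from compound 1 to compound 2 and a 1.0-fold higher number (0.02 log units; within the scatter) from compound 3 to compound 4, 1.1-fold (0.03 log units) apart, within the scatter of two such steps. Within these two pairs, then, the change from 4-nitrophenyl to 4-methylphenyl carries from one core to the other in the sense that neither step can be told from the scatter. This does not show that the two cores respond alike in general, since two steps too small to read reveal only that no effect was seen here, and they set no rule for the wider series.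

From the compounds shown here alone, it remains open whether another group on the same aromatic carbon, such as an amine, a carboxylic acid or a longer chain, would give a step beyond the scatter on either core. Going by these compounds, it also remains open whether such a step would then carry from one core to the other, or whether these results would hold in any other cell line.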